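The compounds below may be only part of what the source reports. "The series", "measured", "known", "first", "only" and "open" are said of these compounds alone.

Compound 1 `O=C(CCC(=O)OCCCCCCSc1ccc([N+](=O)[O-])c2nonc12)Nc1ccccc1Cl`: 335000 nM
Compound 2 `COc1ccccc1NC(=O)CCC(=O)OCCCCCCSc1ccc([N+](=O)[O-])c2nonc12`: 2850 nM
Compound 3 `O=C(CCC(=O)OCCCCCCSc1ccc([N+](=O)[O-])c2nonc12)Nc1cccc(Cl)c1`: 1920 nM

All three values come from a functional assay on HOS cells (Homo sapiens) for inhibition, read by MTT assay, with a stated time of 72 h; on this read-out higher numbers stand for weaker inhibition and lower numbers for stronger inhibition. Compound 3 stands at the low end of the three numbers. That end is shared: a 1.5-fold lower number from compound 2 to compound 3 (0.17 log units; within the scatter). The remaining value lies far off: a 170-fold lower number from compound 1 to compound 3 (2.24 log units; beyond the scatter).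

Compound 4 `Cc1ccc(NC(=O)CCC(=O)OCCCCCCSc2ccc([N+](=O)[O-])c3nonc23)cc1` has not been measured yet. In it, 4-methylphenyl takes the place of 3-chlorophenyl on an amide-type nitrogen (4-methylphenyl in place of 3-chlorophenyl on an amide-type nitrogen). Among the measured compounds shown here, no measured compound carries 4-methylphenyl, so the evidence is indirect. Changing the group on this nitrogen can matter a great deal, as a 120-fold lower number from compound 1 to compound 2 (2.07 log units; beyond the scatter) shows. However, both large steps start from the 2-chlorophenyl group of compound 1, which compound 4 lacks. For the measured compounds named here, the one step without that group is small, and it is the step already given for the shared low end. No step beyond the scatter is therefore expected, although the upper side stays wider. The expected step is a 1.3-fold higher number from compound 3 to compound 4 (0.11 log units; within the scatter). For compound 4 the estimated value is 2500 nM, with an expected range from 900 nM to 10000 nM.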

Compound 4, half-maximal inhibitory concentration: 3340 nM
For compound 4 the middle estimate is 1.3-fold (0.13 log units) below the measured one, within the range that was stated.
By their numbers in this assay, from the lowest: compounds 3, 2 and 4 (each within the scatter of the next); then compound 1.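

In this assay, 4-methylphenyl on the amide-type nitrogen gives a number that cannot be told apart from the two lower values already known: a 1.7-fold higher number from compound 3 to compound 4 (0.24 log units; within the scatter) and a 1.2-fold higher number from compound 2 to compound 4 (0.07 log units; within the scatter). Compound 1 alone stands apart, with a 100-fold lower number from compound 1 to compound 4 (2.00 log units; beyond the scatter), so 3-chlorophenyl, 2-methoxyphenyl and 4-methylphenyl now form one group of closely matched values, while 2-chlorophenyl is the single outlier among the four. Nothing available here accounts for the separate position of that one group.

As far as these compounds go, it remains open whether 2-methylphenyl or 4-chlorophenyl on this nitrogen would stay with the three closely matched compounds or move towards compound 1. Plain phenyl, or a phenyl ring carrying an amine or a carboxylic acid, also remains an open case at this position.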